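Furan-2-yl for 4-Methoxyphenyl and Paw Edema Inhibition

A few compounds are considered here, and "the series" means these few. Any claim that something is new, unique, unknown or untested is made for them only; others in the source may bear on it.

Three compounds have been measured in a functional assay on the whole organism (strain albino) for inhibition, with Rattus norvegicus as the target, read by paw edema, with stated times of 30 min and 4 h, at a dose of 100 mg/kg by the oral route; a lower number here means less inhibition, a higher number more inhibition at the dose given (going by the name of the read-out):
compound 1 `COc1ccc(/C=C/C(=O)c2ccc(NC(=O)C(C)Br)cc2)cc1` gives 38%;
compound 2 `CC(Br)C(=O)Nc1ccc(C(=O)/C=C/c2ccco2)cc1` gives 36%;
compound 3 `COc1ccc(/C=C/C(=O)c2ccc(NC(=O)COc3ccc(C(C)=O)cc3)cc2)cc1` gives 33%.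

Compound 2 differs from compound 1 by furan-2-yl in place of 4-methoxyphenyl on a double-bonded chain carbon bound to a double-bonded chain carbon. This change made a step of a number 2 percentage points lower from compound 1 to compound 2 (within the scatter), a step that lies within the scatter. The difference between the cores of compound 1 and compound 3 is not broken down here. Within the data shown here, compound 4 `CC(=O)c1ccc(OCC(=O)Nc2ccc(C(=O)/C=C/c3ccco3)cc2)cc1` differs from compound 3 by furan-2-yl in place of 4-methoxyphenyl on a double-bonded chain carbon bound to a double-bonded chain carbon, the same change at the same place as the one between compound 1 and compound 2.

For compound 4 the step is expected to be a number 2 percentage points lower from compound 3 to compound 4 (within the scatter), resting on the earlier step of a number 2 percentage points lower from compound 1 to compound 2 (within the scatter) and on the value of compound 3, 33%. Compound 4 is therefore estimated at 31%, with a range from 21% to 41%.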

Compound 4, a percentage reported as inhibition, in the whole organism at one dose (the size of the read-out at that dose, not a potency): 39%
Beside the measured number, compound 4's estimate is 8 percentage points below it; the measured number falls inside the stated range.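

In this assay, furan-2-yl in place of 4-methoxyphenyl gave a number 6 percentage points higher from compound 3 to compound 4 (within the scatter). Set beside the earlier step, the change carries over from one core to the other without a difference that can be told apart: the same change on two cores in this assay, a number 2 percentage points lower (within the scatter) from compound 1 to compound 2 and a number 6 percentage points higher (within the scatter) from compound 3 to compound 4, 8 percentage points apart, within the scatter of two such steps Neither step lies beyond the scatter, so the two cores give no sign of responding differently, but this does not establish a size or direction for the change on either core, nor show that it would act alike on any other.

The compounds shown leave open whether another group in that place, such as thiophen-2-yl or 4-aminophenyl, would move the inhibition of paw edema beyond the scatter. They also leave open how the change behaves on further cores.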